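This account rests on a few compounds, and the source may have more. Where it says the series, first, only, none or still open, it means among the compounds named here.

Compound 1 `CCSC(=S)N1CCN(C(=S)SC(=S)N(C)C)CC1` gives 4480000 nM in an ADME assay on HeLa cells (Homo sapiens) for cytotoxicity, read by MTT assay, with a stated time of 24 h; on this read-out higher numbers stand for weaker inhibition and lower numbers for stronger inhibition. Compound 2 `CCCCSC(=S)N1CCN(C(=S)SC(=S)N(C)C)CC1` reaches only a limit of this assay, > 5000000 nM. Compound 3 `CN(C)C(=S)SC(=S)N1CCN(C(=S)NCc2ccccc2)CC1` likewise sits at a limit, > 5000000 nM. Two of the three values shown sit there (the limit of > 5000000 nM in this assay, at which 2 of the 3 values shown sit), so compound 3 is placed by its steps from the others: an at least 1.1-fold higher number from compound 1 to compound 3 (0.04 log units; that floor lies within the scatter) and a step that the two limits leave unreadable from compound 2 to compound 3. Compound 4 `CN(C)C(=S)SC(=S)N1CCN(C(=S)NC2CCCCC2)CC1` carries cyclohexyl in place of benzyl on an amide-type nitrogen. Going by the values given here, no measured step makes this same change, and both steps reaching compound 3 alter the thiocarbonyl side of the shared core, one of them unreadable. Compound 4 is therefore expected to remain at or near the limit, with a step of a number no higher from compound 3 to compound 4 (the limit leaves the size open). Compound 4 is estimated at 5000000 nM, between 2500000 nM and 10000000 nM.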

Compound 4, half-maximal inhibitory concentration: > 5000000 nM
Compound 4 ended at the assay's limit; the forecaster's own chance of this, stated with the estimate: 75%; the middle value sits exactly at the limit.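

In this assay, compound 4 stands at a limit, so cyclohexyl on the amide-type nitrogen gives the same limit result as benzyl in compound 3. Going by these compounds alone, the steps to compound 4 from compound 2 and compound 3 cannot be read, and the one readable step, an at least 1.1-fold higher number from compound 1 to compound 4 (0.04 log units; that floor lies within the scatter), shows no change beyond the scatter. The limit now covers most of the series: the limit of > 5000000 nM in this assay, at which 3 of the 4 values shown sit.

From the compounds shown here alone, whether any group on this nitrogen brings a value below the limit stays open. A methyl group, or a phenyl ring carrying a carboxylic acid or an amine, would test this.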